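The source may report more compounds than this note shows. Statements on the series, on what has been measured and on what is new or still open speak of the compounds shown alone.

Measured so far:
Compound 1 `CC(NC(=O)N(C)S(=O)(=O)c1ccccc1)c1ccccc1OCc1ccccc1` gives 21700 nM here
Compound 2 `Cc1ccc(S(=O)(=O)N(C)C(=O)NC(C)c2ccccc2OCc2ccccc2)cc1` gives 31000 nM here

In a functional assay on thoracic aorta (Rattus norvegicus, strain Wistar), with a stated time of 15 min (on this read-out higher numbers stand for an effect only at larger amounts of compound and lower numbers for an effect already at smaller amounts), compound 1 and compound 2 lie within the scatter of each other, so neither stands apart. Compound 3 `Cc1ccc(OCc2ccccc2)c(C(C)NC(=O)N(C)S(=O)(=O)c2ccccc2)c1` is not yet measured. It differs from compound 1 by methyl in place of hydrogen on an aromatic carbon, a methyl in place of hydrogen on an aromatic carbon, para to a benzyloxy group. For the measured compounds named here, one measured step bears on this: compound 2 carries the same kind of change at another place, and a 1.4-fold higher number from compound 1 to compound 2 (0.15 log units; within the scatter) stays within the scatter. No step beyond the scatter is therefore expected, and the estimated step is a 1.2-fold higher number from compound 1 to compound 3 (0.06 log units; within the scatter) at most a small one. For compound 3 the expected value is 25000 nM, with an estimated range of 11000 nM to 55000 nM in this assay.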

Compound 3, half-maximal effective concentration: 68200 nM
For compound 3 the middle estimate is 2.7-fold (0.44 log units) below the measured one; measured number above the stated range.
By their numbers in this assay, from the lowest: compounds 1 and 2 (each within the scatter of the next); then compound 3.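

In this assay, methyl in place of hydrogen on an aromatic carbon, para to a benzyloxy group, gives a 3.1-fold higher number from compound 1 to compound 3 (0.50 log units; beyond the scatter) and so moves the number beyond the scatter. The same kind of change at the other place gave only a 1.4-fold higher number from compound 1 to compound 2 (0.15 log units; within the scatter), so the outcome of this change depends on where it sits in these compounds. No measurement is at hand that accounts for this difference. The compounds shown leave open whether an ethyl, a chlorine or an amine at this position would give a comparable step, and whether a longer chain would go further.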